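The source may hold more compounds than are shown below. What is called first, only, known or untested is meant among the compounds shown, and "the series" means these compounds.

Measured so far:
compound 1 `CC(C)n1ncc2c(C(=O)N3CCc4cccnc43)cc(-c3cccs3)nc21`: 50000 nM
compound 2 `CC(C)n1ncc2c(C(=O)Nc3cccnc3)cc(-c3ccsc3)nc21`: 37000 nM

Both values come from an ADME assay on LLC-MK2 cells (Macaca mulatta) for cytotoxicity, read by spectrophotometry and crystal violet staining, with a stated time of 4 days; a lower number here means that less compound is tolerated, a higher number that more compound is tolerated. Compound 2, at 37000 nM, lies within the usual scatter of compound 1, at 50000 nM, so this pair shows no real separation on the numbers available.

The next compound to be read is compound 3 `CC(C)n1ncc2c(C(=O)Nc3cccnc3)cc(-c3cccs3)nc21`. It has the same atoms as compound 2, joined differently, with thiophen-2-yl in place of thiophen-3-yl on an aromatic carbon.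

For the measured compounds named here, no measured pair isolates this exchange, so there is no direct step to carry over. Going by the values given here, the only guide is that compound 1 at 50000 nM and compound 2 at 37000 nM sit close together. In this assay, no step beyond the scatter is expected, and no direction is favoured. The estimated change is a 1.1-fold higher number from compound 2 to compound 3 (0.03 log units; within the scatter), which is expected to be small. For compound 3 the estimate is 40000 nM, with an expected range of 18000 nM to 80000 nM.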

Compound 3, half-maximal cytotoxic concentration: > 200000 nM
Compound 3 was reported as a limit; the forecaster's own chance of this, stated with the estimate: 25%; middle value at least 5.0-fold (0.69 log units) away from the limit.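

Compound 3 stands as a limit and not as a number: the limit of > 200000 nM in this assay, at which 1 of the 3 values shown sits.

Moving only the point of attachment, with thiophen-2-yl in place of thiophen-3-yl on the aromatic carbon next to the ring nitrogen, gives an at least 5.4-fold higher number from compound 2 to compound 3 (0.73 log units; beyond the scatter) in this assay, so this position responds to a change that leaves the atom counts of the group untouched. With thiophen-2-yl held constant, the group of 7 heavy atoms in place of the group of 9 heavy atoms on the carbonyl carbon gives an at least 4.0-fold higher number from compound 1 to compound 3 (0.60 log units; beyond the scatter), so the amide side also carries a step beyond the scatter, something the earlier pair, which differs in two places, could not separate.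

Both steps have only a lower bound, so their true size stays open, and the compounds shown do not tell whether the thiophene exchange would read the same with the group of 9 heavy atoms on the carbonyl carbon. From the compounds shown here alone, how a phenyl, a furan-2-yl or a methyl on that aromatic carbon would read in this assay also stays open.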